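This account rests on a few compounds, and the source may have more. Where it says the series, first, only, none or still open, it means among the compounds named here.

Measured so far in this series:

compound 1 `O=C(/C=C/c1ccc2c(c1)B(O)OC2)c1cccc(F)c1`: > 10 ug/mL
compound 2 `O=C(/C=C/c1ccc2c(c1)B(O)OC2)c1ccc(O)c(O)c1`: > 10 ug/mL
compound 3 `COc1cccc(C(=O)/C=C/c2ccc3c(c2)B(O)OC3)c1`: > 10 ug/mL

The read-out is an ADME assay on L929 cells (Mus musculus) for cytotoxicity, read by resazurin assay, with a stated time of 72 h; a lower number here means a stronger inhibitor, a higher number a weaker inhibitor. For compound 1 the value > 10 ug/mL is a limit of the assay, not a number. For compound 2 the value > 10 ug/mL is likewise a limit. For compound 3 the value > 10 ug/mL is a limit as well. Compound 1 therefore stands only at a limit, and the two further values shown are also limits, so no ordering within the series can be read.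

Among the compounds with values here, the one measured step, a step that the two limits leave unreadable from compound 1 to compound 3, cannot be sized, since both ends sit at the limit. The evidence is summarised in the limit of > 10 ug/mL in this assay, at which 3 of the 3 values shown sit.

The unmeasured compound is compound 4 `Cn1cccc1C(=O)/C=C/c1ccc2c(c1)B(O)OC2`. It differs from compound 1 by 1-methyl-1H-pyrrol-2-yl in place of 3-fluorophenyl on a carbonyl carbon. Within the data shown here, no measured step bears on a change at the carbonyl carbon; the only step, from fluoro to methoxy, is unreadable. Given that compound 1, compound 2 and compound 3 all sit at the limit, compound 4 is expected to show a step that the limit leaves unreadable from compound 1 to compound 4 that is nothing beyond the scatter. In this assay compound 4 is estimated at 20 ug/mL, with a range from 8 ug/mL to 60 ug/mL, most likely reported again only as a limit.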

Compound 4, half-maximal inhibitory concentration: > 10 ug/mL
Compound 4 gave a limit, no number; the forecaster's own chance of this, stated with the estimate: 80%; the middle value lies beyond the limit too.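

In this assay compound 4 gives > 10 ug/mL, which is a limit and not a number. Within the data shown here, compound 1 and compound 4 both stand at a limit, so no step between them can be read: the limit of > 10 ug/mL in this assay, at which 4 of the 4 values shown sit. The compounds shown leave open where any of them has its actual value in this assay, and whether any change to the shared core would give a readable number.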